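Moving compound 1's amide to morpholin-4-yl

A few compounds are considered here, and "the series" means these few. Any claim that something is new, unique, unknown or untested is made for them only; others in the source may bear on it.

Compound 1 `CCCCCC[C@@H](O)C/C=C\CCCCCCCC(=O)N[C@@H](C)c1ccccc1`: 5.1 ug/mL
Compound 2 `CCCCC/C=C\C/C=C\CCCCCCCC(=O)N1CCCCC1`: 22.1 ug/mL
Compound 3 `CCCCCCCCCCCCCCCC(=O)N1CCOCC1`: 15.4 ug/mL

In a functional assay on MCF7 cells (Homo sapiens) for antiproliferative activity, read by sulforhodamine B assay, with a stated time of 48 h (on this read-out lower numbers stand for stronger inhibition of growth and higher numbers for weaker inhibition of growth), compound 1 has the lowest number of the three, and its gaps to compound 2 and compound 3 both lie beyond the scatter. Compound 4 `CCCCCC[C@@H](O)C/C=C\CCCCCCCC(=O)N1CCOCC1` keeps the core of compound 1 but has morpholin-4-yl in place of (1-phenylethyl)amino on a carbonyl carbon. Going by the values given here, no two measured compounds differ in only one place, so no measured step guides this estimate. Compound 3, which also carries morpholin-4-yl, gives 15.4 ug/mL, which suggests weaker growth inhibition. The expected change in this assay is a 2.4-fold higher number from compound 1 to compound 4 (0.37 log units; beyond the scatter). For compound 4, the estimated value is 12 ug/mL, with an expected range of 5 ug/mL to 28 ug/mL.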

Compound 4, concentration for 50% growth inhibition: 41.8 ug/mL
Compound 4: the middle estimate sits 3.5-fold (0.54 log units) below what was measured; the measured number lies above the stated range.
By their numbers in this assay, from the lowest: compound 1; then compounds 3, 2 and 4 (each within the scatter of the next, the first and the last beyond it).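

In this assay, going by these compounds alone, the one step measured at this position is an 8.2-fold higher number from compound 1 to compound 4 (0.91 log units; beyond the scatter), showing that with the core of compound 1 held fixed, the group on the carbonyl carbon strongly affects growth inhibition. This change removes the six-membered aromatic ring and the hydrogen-bond donor together, so this step cannot show which loss matters. No measurement here explains the difference. On these data alone, a cyclohexylamino group on the same carbonyl carbon would keep the amide hydrogen without an aromatic ring, and its effect remains open. As far as these compounds go, whether the stereocentre in (1-phenylethyl)amino matters also remains open.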